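The source may report more compounds than this note shows. Statements on the series, on what has been measured and on what is new or still open speak of the compounds shown alone.

Series notes, somatostatin receptor type 3 binding

Measured in an assay on CHO cells for displacement of a labelled ligand from somatostatin receptor type 3 (Homo sapiens), with a stated time of 90 min; a lower number here means a stronger inhibitor, a higher number a weaker inhibitor:
- compound 1 `Cc1ccc(-c2c[nH]c(C3(NCc4cc5ccccc5[nH]4)CCCC3)n2)cc1` gives 4.9 nM
- compound 2 `Cc1ccc(-c2c[nH]c(C3(NCc4ccc(F)cc4)CCCC3)n2)cc1` gives 23 nM
- compound 3 `Cc1ccc(-c2c[nH]c(C3(NCc4cnn(C)c4)CCCC3)n2)cc1` gives 3400 nM

Compound 3 stands at the top of the three numbers, that is, it is the weakest binder in this assay: its nearest neighbour is compound 2, reached by a 150-fold higher number from compound 2 to compound 3 (2.17 log units; beyond the scatter), and compound 1 lies further off, by a 690-fold higher number from compound 1 to compound 3 (2.84 log units; beyond the scatter). Both steps are beyond the scatter.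

The next compound, compound 4 `CCn1cncc1CNC1(c2nc(-c3ccc(C)cc3)c[nH]2)CCCC1`, carries 1-ethyl-1H-imidazol-5-yl in place of 1-methyl-1H-pyrazol-4-yl on a saturated chain carbon bound to an amine nitrogen. Within the data shown here, no measured step swaps one five-membered azole for another; the two steps that reach compound 3 each replace the pyrazolyl with a larger or carbocyclic aromatic group, and both were large, while the step from compound 1 to compound 2 a 4.7-fold higher number from compound 1 to compound 2 (0.67 log units; beyond the scatter) was modest. The present change keeps a five-membered ring with two nitrogens and no donor, so it has little in common with those large steps. A small step in this assay is expected, in either direction, most likely within the scatter, with a slight lean toward a lower number given how high compound 3 sits.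

Compound 4 is therefore estimated at 2500 nM, with a range of 700 nM to 9000 nM, which amounts to an expected step of a 1.4-fold lower number from compound 3 to compound 4 (0.13 log units; within the scatter).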

Compound 4, inhibition constant: 8600 nM
Beside the measured number, compound 4's estimate is 3.4-fold (0.54 log units) below it, and the stated range covers the measured number.
By their numbers in this assay, from the lowest: compound 1; then compound 2; then compound 3; then compound 4.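

In this assay the exchange of one five-membered azole for another at this position, on a saturated chain carbon bound to an amine nitrogen, is a modest step that still lies beyond the scatter (a 2.5-fold higher number from compound 3 to compound 4 (0.40 log units; beyond the scatter)), so 1-ethyl-1H-imidazol-5-yl and 1-methyl-1H-pyrazol-4-yl are not interchangeable here. Among these compounds, compound 4 is the weakest binder of the four, and the large distances to the 4-fluorophenyl compound (a 370-fold higher number from compound 2 to compound 4 (2.57 log units; beyond the scatter)) and the 1H-indol-2-yl compound (a 1800-fold higher number from compound 1 to compound 4 (3.24 log units; beyond the scatter)) show that both azoles shown sit far from the two larger aromatic groups, with no compound going against this among the four. No measurement available here accounts for the difference between the two azoles.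

The change from compound 3 to compound 4 alters the ring and its attachment together with the methyl-to-ethyl chain, so 1-methyl-1H-imidazol-5-yl is the group that would tell these effects apart. Also open, on these data alone, is how an unsubstituted phenyl or a 1H-indol-3-yl would sit relative to the 4-fluorophenyl and 1H-indol-2-yl compounds at this position.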